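This account rests on a few compounds, and the source may have more. Where it says the series, first, only, none or still open, it means among the compounds named here.

In a physicochemical assay for solubility, in phosphate buffer, with a stated time of 24 h, at pH 7.4, tested at 100 uM (a lower number here means a less soluble compound, a higher number a more soluble compound), compound 1 (`CCCn1cc(S(=O)(=O)c2ccc(CNC(=O)N3Cc4ccncc4C3)cc2)cn1`) gives 105000 nM while compound 2 (`O=C(NCc1ccc(S(=O)(=O)C2CCC(F)(F)CC2)cc1)N1Cc2ccncc2C1`) gives 35000 nM and compound 3 (`CN1CCC(S(=O)(=O)c2ccc(CNC(=O)N3Cc4ccncc4C3)cc2)CC1`) gives 240000 nM as the highest of the three. Compound 4 (`O=C(NCc1ccc(S(=O)(=O)N2CCC[C@H](O)C2)cc1)N1Cc2ccncc2C1`) has 3-hydroxypiperidin-1-yl in place of 1-methylpiperidin-4-yl on a sulfonyl sulfur. For the measured compounds named here, no measured compound carries the entering group, so the only guides are the swaps at that sulfur. These give a 3.0-fold lower number from compound 1 to compound 2 (0.48 log units; beyond the scatter) along with a 2.3-fold higher number from compound 1 to compound 3 (0.36 log units; beyond the scatter) and a 6.9-fold higher number from compound 2 to compound 3 (0.84 log units; beyond the scatter) and all are modest. With compound 3 at 240000 nM on top of the series, a modest fall is expected. The step expected in this assay is a 2.4-fold lower number from compound 3 to compound 4 (0.38 log units; beyond the scatter) and so runs downward. The estimate for compound 4 is 100000 nM with 40000 nM to 220000 nM as its expected range.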

Compound 4, solubility: 215000 nM
The estimate for compound 4 lay 2.2-fold (0.33 log units) below the measured number; measured number inside the range.
By their numbers in this assay, from the lowest: compound 2; then compound 1; then compounds 4 and 3 (each within the scatter of the next).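

In this assay, 3-hydroxypiperidin-1-yl on the sulfonyl sulfur, with its hydrogen-bond donor and defined stereocentre, cannot be told apart from 1-methylpiperidin-4-yl (a 1.1-fold lower number from compound 3 to compound 4 (0.05 log units; within the scatter)). It keeps the clear gains over 4,4-difluorocyclohexyl (a 6.1-fold higher number from compound 2 to compound 4 (0.79 log units; beyond the scatter)) and over 1-propyl-1H-pyrazol-4-yl (a 2.0-fold higher number from compound 1 to compound 4 (0.31 log units; beyond the scatter)), so two different groups now share the top of the series. No evidence is available that bears on this result. The compounds shown leave open whether piperidin-1-yl without the hydroxyl, or morpholin-4-yl, would give a similar number.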